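Benzyloxy on the core: a forecast from three measurements

The source may hold more compounds than are shown below. What is called first, only, known or untested is meant among the compounds shown, and "the series" means these compounds.

Three compounds share a core built from a sulfonyl-linked aromatic ring, a fused two-ring system and a pyridine carrying trifluoromethyl. Compound 1 `COc1ccc2c(c1)c(-c1cc(C(F)(F)F)ccn1)cn2S(=O)(=O)c1ccc(C)cc1` gives 16.9% in a functional assay on A549 cells (Homo sapiens) for inhibition, tested at 0.1 uM; a higher number here means a stronger effect of the compound at the concentration tested, a lower number a weaker effect. Compound 2 `Cc1ccc(S(=O)(=O)n2cc(-c3cc(C(F)(F)F)ccn3)c3ccccc32)cc1` gives 25% in this assay, the second highest of the three numbers, close to compound 3 `Cc1ccc(S(=O)(=O)n2cc(-c3cc(C(F)(F)F)cc(-c4cn(S(=O)(=O)c5ccc(C)cc5)c5cc(Br)ccc45)n3)c3ccc(Br)cc32)cc1`, which gives 25.8% in this assay, and close to compound 1 as well, so no order can be read among them.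

The compound to be estimated is compound 4 `Cc1ccc(S(=O)(=O)n2cc(-c3cc(C(F)(F)F)ccn3)c3cc(OCc4ccccc4)ccc32)cc1`. It differs from compound 2 by one change: benzyloxy in place of hydrogen on an aromatic carbon. Within the data shown here, the only measured step that touches this part of the core is the one from compound 1 to compound 2, a number 8.1 percentage points higher from compound 1 to compound 2 (within the scatter), where a methoxy group was replaced by hydrogen on an aromatic carbon. Among the measured compounds shown here, that step stayed inside the scatter, so the numbers so far give no sign that a group at this kind of position moves the read-out.

Compound 4 is therefore expected to stay near compound 2, with a step of a number 3 percentage points lower from compound 2 to compound 4 (within the scatter) that is itself within the scatter. The estimate for compound 4 in this assay is 22%, within a range from 5% to 45%.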

Compound 4, a percentage reported as inhibition, at one concentration (the size of the read-out at that concentration, not a potency): 16.9%
Compound 4: middle estimate off by 5.1 percentage points, on the high side; the measured number falls inside the stated range.
By their numbers in this assay, from the lowest: compounds 1, 4, 2 and 3 (each within the scatter of the next).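

In this assay, benzyloxy on this aromatic carbon, meta to a fused ring and para to a fused ring, gives a number 8.1 percentage points lower from compound 2 to compound 4 (within the scatter), so even a group of 8 heavy atoms carrying its own six-membered aromatic ring produces no step beyond the scatter here. Extending the methoxy group of compound 1 to benzyloxy, with phenyl in place of hydrogen on the saturated chain carbon, gives no change at the digits printed from compound 1 to compound 4 (within the scatter), so the read-out at this single concentration does not separate the small ether from the much larger one. Nothing among the data offers an explanation for these numbers.

Going by these compounds, whether an amine or a carboxylic acid on this same aromatic carbon would give a step beyond the scatter remains open, and so does the effect of a longer chain in place of benzyloxy. Each compound is represented by a read-out at only one concentration, so these results also leave open whether the compounds would show a stronger or weaker effect than one another at any other concentration.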